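The compounds below may be only part of what the source reports. "The series", "measured", "known", "first", "only" and "open" are said of these compounds alone.

Compound 1 `Cc1cc(C(=O)c2ccccc2)ccc1OCC(=O)Nc1nc(-c2ccccc2)cs1` gives 22300 nM in a functional assay on Ehrlich cells (Mus musculus) for cytotoxicity, read by trypan blue exclusion, with a stated time of 48 h (on this read-out lower numbers stand for stronger inhibition and higher numbers for weaker inhibition), and of the two numbers recorded it stands level with compound 2 `Cc1cc(C(=O)c2ccccc2)cc(C)c1OCC(=O)Nc1nc(-c2ccccc2)cs1`, which gives 22100 nM in this assay, the step of a 1.0-fold lower number from compound 1 to compound 2 (0.00 log units; within the scatter) lying within the scatter. Compound 3 `O=C(COc1ccc(C(=O)c2ccccc2)cc1Br)Nc1nc(-c2ccccc2)cs1` has not yet been measured in this assay. It differs from compound 1 by bromo in place of methyl on an aromatic carbon, with the bromo entering on an aromatic carbon of a six-membered aromatic ring of carbon only, ortho to a large group and meta to a benzoyl group. Among the measured compounds shown here, no measured step swaps methyl for bromo. For the measured compounds named here, the only step at hand, a 1.0-fold lower number from compound 1 to compound 2 (0.00 log units; within the scatter), places a methyl on an aromatic carbon of the same ring and leaves the number where it was, so the one substituent change seen so far did not move this assay. The estimated step of a 1.1-fold lower number from compound 1 to compound 3 (0.05 log units; within the scatter) is therefore expected to be small, within the scatter. Compound 3 is expected to give about 20000 nM in this assay, with a range from 8000 nM to 50000 nM.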

Compound 3, half-maximal inhibitory concentration: 45800 nM
For compound 3 the middle estimate is 2.3-fold (0.36 log units) below the measured one, and the stated range covers the measured number.
By their numbers in this assay, from the lowest: compounds 2 and 1 (each within the scatter of the next); then compound 3.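

Bromo in place of methyl on this aromatic carbon, ortho to a large group and meta to a benzoyl group, gives a 2.1-fold higher number from compound 1 to compound 3 (0.31 log units; beyond the scatter) in this assay, a modest weakening of inhibition. This is the first change among those shown to move the number beyond the scatter on this ring, whereas the added methyl of a 1.0-fold lower number from compound 1 to compound 2 (0.00 log units; within the scatter) did not, so the ring does not tolerate every substituent change equally. Nothing measured here bears on what lies behind this step.

Going by these compounds, with only methyl and bromo compared at this carbon, it remains open whether chloro or methoxy would give a number closer to that of methyl or bromo. On these data alone, how an amine or a carboxylic acid would fare at this carbon also remains open.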